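A few compounds are considered here, and "the series" means these few. Any claim that something is new, unique, unknown or untested is made for them only; others in the source may bear on it.

The set comprises three measured compounds and one awaiting measurement, all tested in a functional assay on SK-MEL-2 cells (Homo sapiens) for cytotoxicity, read by sulforhodamine B assay, with a stated time of 48 h; on this read-out higher numbers stand for lower toxicity in this test and lower numbers for higher toxicity in this test. Compound 1, `ClCc1ccccc1Cn1cnc2c(Cl)ncnc21`, reaches only a limit of the assay: in this assay compound 1 gives > 100000 nM. Compound 2, `ClCc1cccc(Cn2cnc3ncnc(Cl)c32)c1`, returns a number; in this assay compound 2 gives 6760 nM. Compound 3, `ClCc1cccc(Cn2cnc3c(Cl)ncnc32)c1`, again stops at a limit: in this assay compound 3 gives > 100000 nM. For the measured compounds named here, compound 3 therefore stands together with compound 1 at the limit of > 100000 nM in this assay, at which 2 of the 3 values shown sit, while compound 2 alone yields a measured value; no step between any two of the measured compounds is counted here. The unmeasured compound 4, `ClCc1cccc(Cn2cnc3c(Cl)nc(Cl)nc32)c1`, differs from compound 3 in one place: chloro in place of hydrogen on an aromatic carbon, between two ring nitrogen atoms, meta to a chloro group, meta to a fused ring and para to a fused ring. Compound 3 sits at a limit, so the size of the step to compound 4 cannot be read from a number; the writer expects the step of an at least 2.5-fold lower number from compound 3 to compound 4 (0.39 log units; beyond the scatter) to be modest and toward a measurable number, if beyond the scatter at all. Compound 4 is estimated at 40000 nM, within a range from 8000 nM to 150000 nM, with a fair chance that it too returns only a limit.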

Compound 4, concentration lethal to 50% of the cells: 10000 nM
For compound 4 the middle estimate is 4.0-fold (0.60 log units) above the measured one, and the stated range covers the measured number.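

In this assay, chloro in place of hydrogen on an aromatic carbon, between two ring nitrogen atoms, gives the only readable step among these compounds, an at least 10-fold lower number from compound 3 to compound 4 (1.00 log units; beyond the scatter). This shows that the position is not silent: with chloro there, compound 4 returns a measured number, whereas compound 3, which carries hydrogen there, stops at a limit of the assay. The true size of the step stays unknown because the starting value of compound 3 is a limit and not a number: the limit of > 100000 nM in this assay, at which 2 of the 4 values shown sit.

The compounds shown place only hydrogen and chloro at this position, so it remains open whether an amine, a methoxy group or a longer chain there would also bring a measured number, and how large any such step would be. Going by these compounds, it also remains open whether the same change would lower the number on compound 1 or compound 2, and these values alone cannot tell what in the chloro group produces the step.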